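The compounds below may be only part of what the source reports. "The series", "measured", "known", "first", "only" and "open" are said of these compounds alone.

Compound 1 has the structure `CNCC(=O)Nc1cc(OC)ccc1C(=O)c1ccc(OC)c2c1C=CC(C)(C)O2`. In a functional assay on A549 cells (Homo sapiens) for antiproliferative activity, read by MTT assay, with a stated time of 48 h (a higher number here means a weaker inhibitor, a lower number a stronger inhibitor), compound 1 gives 1370 nM. Compound 2, `CCNCC(=O)Nc1cc(OC)ccc1C(=O)c1ccc(OC)c2c1C=CC(C)(C)O2`, differs from compound 1 in one place: methyl in place of hydrogen on a saturated chain carbon bound to an amine nitrogen. In this assay compound 2 gives 2310 nM. That change produced a 1.7-fold higher number from compound 1 to compound 2 (0.23 log units; within the scatter).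

Compound 3, `CNCC(=O)Nc1cc(OC)ccc1C(=O)c1cc(OC)c(OC)c(OC)c1`, carries a different core; how its core differs from that of compound 1 is not broken down here. In this assay compound 3 gives 610 nM, the lowest of the three numbers. Compound 1 lies a step above it that is beyond the usual scatter, and compound 2 lies further above it still, also beyond the scatter, so compound 3 is the strongest inhibitor among the three measured compounds.

Compound 4, `CCNCC(=O)Nc1cc(OC)ccc1C(=O)c1cc(OC)c(OC)c(OC)c1`, has not yet been measured. It stands to compound 3 as compound 2 stands to compound 1: the difference is methyl in place of hydrogen on a saturated chain carbon bound to an amine nitrogen. For the measured compounds named here, the place of the change is described in the same words in both pairs, so this is the same change made on a second core, and the one earlier instance is the only guide to its size. Because that instance gave a 1.7-fold higher number from compound 1 to compound 2 (0.23 log units; within the scatter), the step expected here is a 1.6-fold higher number from compound 3 to compound 4 (0.21 log units; within the scatter). On this basis compound 4 is estimated at 1000 nM in this assay. The likely range for compound 4 is expected to run from 500 nM to 2100 nM, wide enough to allow for the usual scatter around a single earlier step.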

Compound 4, half-maximal inhibitory concentration: 750 nM
The estimate for compound 4 lay 1.3-fold (0.12 log units) above the measured number; low and high end bracket the measured number.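

Replacing the methylamino group with ethylamino on the second core gives a 1.2-fold higher number from compound 3 to compound 4 (0.09 log units; within the scatter) in this assay, so this step cannot be told apart from the ordinary variation between repeat measurements. Set beside the earlier step, the same change behaves alike on the two cores: the same change on two cores in this assay, a 1.7-fold higher number (0.23 log units; within the scatter) from compound 1 to compound 2 and a 1.2-fold higher number (0.09 log units; within the scatter) from compound 3 to compound 4, 1.4-fold (0.14 log units) apart, within the scatter of two such steps This shows that, for these two pairs, the change carries from one core to the other without a detectable difference in its size, but it rests on only two small steps, both lost in the scatter, so it does not establish a rule for other cores, and it does not explain why the numbers came out this way.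

The compounds shown stop at methylamino and ethylamino, leaving open what a longer chain such as propylamino, a branched group such as isopropylamino, or a ring amine such as pyrrolidine would do on either core. They also leave open whether any change at this end of the side chain can produce a step beyond the scatter, and whether the two cores would still respond alike if it did.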